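Iodophenyl for methyl on the ring amine of compound 1

The compounds below may be only part of what the source reports. "The series", "measured", "known", "first", "only" and "open" are said of these compounds alone.

Compound 1 `CCCn1c(=O)[nH]c2nc(-c3ccc(S(=O)(=O)N4CCN(C)CC4)cc3)[nH]c2c1=O` was tested in an assay on CHO cells for displacement of a labelled ligand from adenosine receptor A3 (Homo sapiens), read by scintillation counting, with a stated time of 45 min, tested at 1 uM, in the presence of a further agent that is not named here (on this read-out lower numbers stand for less inhibition and higher numbers for more inhibition at the one concentration tested (going by the name of the read-out)), where compound 1 gives 7%. Compound 2 `CCCn1c(=O)[nH]c2nc(-c3ccc(S(=O)(=O)N4CCN(c5ccccc5)C(C)C4)cc3)[nH]c2c1=O` in this assay gives -2%, and the two values sit within the usual scatter of each other, so neither can be placed above the other. Compound 3 `CCCn1c(=O)[nH]c2nc(-c3ccc(S(=O)(=O)N4CCN(c5ccc(I)cc5)CC4)cc3)[nH]c2c1=O` differs from compound 1 by 4-iodophenyl in place of methyl on an amine nitrogen in a ring. Among the measured compounds shown here, no measured pair shows the effect of such a change, so only a small step is expected in this assay, in either direction and not beyond the scatter. For compound 3 the estimated value in this assay is 3%, between -10% and 16%, a step of a number 4 percentage points lower from compound 1 to compound 3 (within the scatter) that is expected to stay within the scatter.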

Compound 3, a percentage reported as inhibition, at one concentration (the size of the read-out at that concentration, not a potency): 36%
Beside the measured number, compound 3's estimate is 33 percentage points below it, and the stated range ends below it.
By their numbers in this assay, from the lowest: compounds 2 and 1 (each within the scatter of the next); then compound 3.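

Placing 4-iodophenyl in place of methyl on the amine nitrogen in the ring gives a number 29 percentage points higher from compound 1 to compound 3 (beyond the scatter) in this assay. Among the compounds shown here, this is the first sign that this position responds to a change of group, which compound 2 could not show, since it differs from compound 1 in more than one place. Nothing at hand explains the rise. Going by these compounds, whether it follows from the six-membered aromatic ring or from the iodine stays open; an unsubstituted phenyl or a 4-bromophenyl on this nitrogen would separate the two.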